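A few compounds are considered here, and "the series" means these few. Any claim that something is new, unique, unknown or untested is made for them only; others in the source may bear on it.

Measured compounds:
- compound 1 `COc1ccc(/C=C/C(=O)Nc2cc3c(Nc4ccc(F)c(Cl)c4)ncnc3cc2OC)c(OC)c1`: 33300 nM
- compound 2 `COc1cc(/C=C/C(=O)Nc2cc3c(Nc4ccc(F)c(Cl)c4)ncnc3cc2OC)cc(OC)c1`: "not active" (no number reported), with no number
- compound 3 `COc1cc(/C=C/C(=O)Nc2cc3c(Nc4ccc(F)c(Cl)c4)ncnc3cc2O[C@H]2CCOC2)cc(OC)c1`: 10800 nM

All three share the same core, and all were tested in a functional assay on A549 cells (Homo sapiens) for cytotoxicity, read by MTT assay, with a stated time of 72 h; a higher number here means a weaker inhibitor, a lower number a stronger inhibitor. In this assay compound 1 gives 33300 nM, and compound 3 gives 10800 nM, a lower number than compound 1. Compound 2 stands apart: in this assay compound 2 was recorded only as "not active" (no number reported), so no number can be placed beside the other two, and nothing can be said about how far it lies from compound 1 or compound 3.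

Compound 4 `COc1cc2ncnc(Nc3ccc(F)c(Cl)c3)c2cc1NC(=O)/C=C/c1ccc(C#N)cc1` differs from compound 2 in one place: 4-cyanophenyl in place of 3,5-dimethoxyphenyl on a double-bonded chain carbon bound to a double-bonded chain carbon. Among the compounds with values here, no measured pair shows the effect of this change, so the expectation rests only on the weak numbers of the whole set. Compound 2 gave no number at all, and compound 1 gives 33300 nM, so compound 4 is expected to be a weak inhibitor in this assay, with a real chance that it too is reported without a number. On that basis the estimate for compound 4 is 30000 nM, within a range of 8000 nM to 100000 nM.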

Compound 4, half-maximal inhibitory concentration: "not active" (no number reported)
The entry for compound 4 holds no number, and the estimate cannot be compared.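

In this assay both compound 2 and compound 4 are recorded only as "not active", with no number for either, so no step can be read between compound 2 and compound 4. No measured evidence bears on this result. As far as these compounds go, whether 4-cyanophenyl in place of 3,5-dimethoxyphenyl changes activity at all, and by how much, stays open.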